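The source may report more compounds than this note shows. Statements on the series, on what has been measured and on what is new or still open speak of the compounds shown alone.

Compound 1 `CN1CCN(c2ccc(Nc3ncc4nc([S+]([O-])c5ccccc5)n(C5CCOCC5)c4n3)cc2)CC1`: 411 nM
Compound 2 `CN(C)CCN(C)c1ccc(Nc2ncc3nc([S+]([O-])c4ccccc4)n(C4CCOCC4)c3n2)cc1`: 1330 nM
Compound 3 `CN(C)CCN(C)c1ccc(Nc2ncc3nc(Sc4ccccc4)n(C4CCOCC4)c3n2)cc1`: 499 nM

These three compounds share a core and were tested in a functional assay on HCC827 cells (Homo sapiens) for antiproliferative activity, read by MTT assay, with a stated time of 72 h; a lower number here means a stronger inhibitor, a higher number a weaker inhibitor. Compound 2 stands at the highest number of the three: compound 3 lies nearer, and compound 1 is furthest away. The step from compound 2 to compound 4 `CN(C)C1CCN(c2ccc(Nc3ncc4nc([S+]([O-])c5ccccc5)n(C5CCOCC5)c4n3)cc2)CC1` changes the group on the aromatic carbon: 4-(dimethylamino)piperidin-1-yl in place of (2-(dimethylamino)ethyl)(methyl)amino on an aromatic carbon. Going by the values given here, the one measured step that bears on this is the change of the same group, where a ring was replaced by an open chain and the number rose, a 3.2-fold higher number from compound 1 to compound 2 (0.51 log units; beyond the scatter). Compound 4 brings a ring back to that position, a six-membered one as in compound 1, although with a different arrangement of its two nitrogens. The step of a 2.7-fold lower number from compound 2 to compound 3 (0.43 log units; beyond the scatter) changes a different part of the molecule and does not speak to this position. A modest drop in the number from compound 2 to compound 4 is therefore expected, roughly reversing the earlier step, so compound 4 is estimated to land near compound 1 at 450 nM, within 180 nM to 1100 nM, which means an expected step of a 3.0-fold lower number from compound 2 to compound 4 (0.47 log units; beyond the scatter).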

Compound 4, half-maximal inhibitory concentration: 1290 nM
Beside the measured number, compound 4's estimate is 2.9-fold (0.46 log units) below it, outside the stated range (above it).
By their numbers in this assay, from the lowest: compounds 1 and 3 (each within the scatter of the next); then compounds 4 and 2 (each within the scatter of the next).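

In this assay, putting 4-(dimethylamino)piperidin-1-yl in place of the open chain (2-(dimethylamino)ethyl)(methyl)amino gives a 1.0-fold lower number from compound 2 to compound 4 (0.01 log units; within the scatter) and so shows that a six-membered ring at this position does not by itself bring the number down. The two rings are not interchangeable either: 4-(dimethylamino)piperidin-1-yl in place of 4-methylpiperazin-1-yl gives a 3.1-fold higher number from compound 1 to compound 4 (0.50 log units; beyond the scatter) and so ties the lower number of compound 1 to that particular group, not to ring closure in general. Nothing measured here explains why these two rings differ.

Still open, from the compounds shown here alone, is whether a morpholin-4-yl ring, or a piperazin-1-yl ring without its methyl group, would match 4-methylpiperazin-1-yl. Going by these compounds, it is also open whether the change in the sulfur-linked group between compound 2 and compound 3 would carry over to the ring-bearing compounds.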